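This account rests on a few compounds, and the source may have more. Where it says the series, first, only, none or still open, it means among the compounds named here.

Measured so far in a functional assay on HepG2 cells (Homo sapiens) for antiproliferative activity, read by CCK-8 assay, with a stated time of 72 h, tested at 8 uM; on this read-out lower numbers stand for a weaker effect and higher numbers for a stronger effect at the one concentration tested:

compound 1, `CCC(C)n1cnc2c(NCc3ccc(C(=O)Nc4ccccc4N)cc3)nc(Cl)nc21`, gives 65%
compound 2, `Cc1ccc(Nc2nc(Cl)nc3c2ncn3Cc2ccc(C(=O)Nc3ccccc3N)cc2)cc1`, gives 82%

Of these two numbers, compound 1 stands lowest. Its nearest neighbour is compound 2, which sits higher by a margin that is beyond the usual scatter of repeated measurements, so the two compounds are genuinely told apart on this read-out.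

The compound still to be measured is compound 3, `CC(C)n1cnc2c(NCc3ccc(C(=O)Nc4ccccc4N)cc3)nc(Cl)nc21`. It differs from compound 1 in one place only: hydrogen in place of methyl on a saturated chain carbon, two bonds along the chain from an aromatic nitrogen. Cut one bond further out, the same change reads ethyl to methyl, or sec-butyl to isopropyl, so the chain on that position simply becomes one carbon shorter.

Among the measured compounds shown here, no pair of measured compounds that differ in a single place is available here, so there is nothing to anchor how large such a trimming of a chain might be on this read-out. The removed piece is small, with no ring, no hydrogen-bond donor or acceptor and no charge. On that basis the step is expected to be small, and a step of a number 5 percentage points lower from compound 1 to compound 3 (within the scatter) from compound 1 to compound 3 is estimated, which would stay within the scatter. Compound 3 is therefore expected to give about 60%, with a plausible range from 45% to 75%.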

Compound 3, a percentage reported as inhibition, at one concentration (the size of the read-out at that concentration, not a potency): 74.4%
Beside the measured number, compound 3's estimate is 14.4 percentage points below it, and the stated range covers the measured number.
By their numbers in this assay, from the lowest: compounds 1, 3 and 2 (each within the scatter of the next, the first and the last beyond it).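

In this assay, among the compounds shown here, the first comparison that changes a single place reads a number 9.4 percentage points higher from compound 1 to compound 3 (within the scatter) for hydrogen in place of methyl on a saturated chain carbon, two bonds along the chain from an aromatic nitrogen. At the one concentration tested, then, sec-butyl and isopropyl cannot be told apart at this position on the shared core, so trimming the chain by one carbon gives no reliable change in the read-out. No measurement of any property of these groups is available to account for this step.

The compounds shown leave open how far this tolerance extends, for example whether a shorter ethyl or methyl group, a longer chain such as n-hexyl, or a ring such as cyclopentyl would leave the read-out equally unchanged. They also leave open whether an amine or a carboxylic acid carried on the chain would shift the effect, and a percentage at one concentration cannot show whether potency differs between sec-butyl and isopropyl.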